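A few compounds are considered here, and "the series" means these few. Any claim that something is new, unique, unknown or untested is made for them only; others in the source may bear on it.

Measured compounds in a functional assay on A2780 cells (Homo sapiens) for antiproliferative activity, read by MTT assay, with a stated time of 48 h; on this read-out higher numbers stand for weaker inhibition and lower numbers for stronger inhibition:
Compound 1, `COc1cc(C(=O)/C=C/c2cn(C)c3ccccc23)cc(N)c1OC`: 441 nM
Compound 2, `COc1cc(C(=O)/C=C/c2cn(C)c3ccccc23)cc(SC)c1OC`: 193 nM
Compound 3, `COc1cc(C(=O)/C(C)=C/c2c[nH]c3ccccc23)cc([Se]C)c1OC`: 25 nM

Among these three numbers compound 2 stands second highest. Within the data shown here, compound 1 gives the higher number, and the only single-change step in the set runs between these two: a 2.3-fold lower number from compound 1 to compound 2 (0.36 log units; beyond the scatter). Compound 3 gives the lowest number of the three, but it differs from compound 2 in more than one place, so its value shows only where it stands, not what any one change did.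

Compound 4, `COc1ccc2c(/C=C/C(=O)c3cc(OC)c(OC)c(SC)c3)cn(C)c2c1`, is the next step from compound 2. The change is methoxy in place of hydrogen on an aromatic carbon. Among the measured compounds shown here, it sits on the opposite part of the shared core from the change that separates compound 1 and compound 2, and no measured pair shows this change by itself. For the measured compounds named here, the one measured step, modest in size, concerns a different group and does not bear directly on this one. Going by the values given here, with no comparable step in the data, the expectation is a step that stays within the usual scatter, in either direction.

Compound 4 is therefore estimated at 160 nM in this assay, with a likely range from 50 nM to 500 nM. This estimate amounts to an expected 1.2-fold lower number from compound 2 to compound 4 (0.08 log units; within the scatter).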

Compound 4, half-maximal inhibitory concentration: 145 nM
Estimate against measurement, compound 4: 1.1-fold (0.04 log units) above, within the range that was stated.
By their numbers in this assay, from the lowest: compound 3; then compounds 4 and 2 (each within the scatter of the next); then compound 1.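

In this assay, among these compounds, the methoxy in place of hydrogen gives a 1.3-fold lower number from compound 2 to compound 4 (0.12 log units; within the scatter), the first reading at this aromatic carbon, which is meta to a fused ring and para to a fused ring. The earlier compounds shown here all carry hydrogen there, so they could say nothing about a substituent at this place; this single pair shows that the core of compound 2 accepts methoxy here with no difference that can be told from the scatter, and it shows this for this one pair only. No supporting measurement bears on this result, so the step stands without an explanation.

As far as these compounds go, whether the same holds for other groups on this carbon, such as a hydroxy group, a fluorine atom or an ethoxy chain, stays open, and so does whether methoxy would fare the same on another carbon of this six-membered ring. Also open, from the compounds shown here alone, is whether this change would give a similar step on the core of compound 3 , which gives 25 nM and differs from compound 2 in more than one place.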